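Basic side chains on the shared core: antiproliferative read-out

The compounds below may be only part of what the source reports. "The series", "measured", "known", "first", "only" and "open" are said of these compounds alone.

Measured so far:
compound 1 `COc1cc(OC)c2c(=O)cc(-c3ccc(OC4CCN(C)CC4)cc3)oc2c1`: 28%
compound 2 `COc1cc(OC)c2c(=O)cc(-c3ccc(Br)cc3)oc2c1`: 12%

In a functional assay (Homo sapiens) for antiproliferative activity, read by resazurin assay, with a stated time of 48 h, tested at 5 uM (on this read-out lower numbers stand for a weaker effect and higher numbers for a stronger effect at the one concentration tested), compound 1 gives 28% and compound 2 gives 12%. Among the compounds with values here, compound 2 stands lowest of the two numbers; the one step measured, a number 16 percentage points lower from compound 1 to compound 2 (beyond the scatter), is beyond the scatter and marks the loss of the (1-methylpiperidin-4-yl)oxy group for bromo.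

Compound 3 `COc1cc(OC)c2c(=O)cc(-c3ccc(NCCN4CCCC4)cc3)oc2c1` is not yet measured. It differs from compound 2 by (2-(pyrrolidin-1-yl)ethyl)amino in place of bromo on an aromatic carbon. Within the data shown here, the only step that bears on it is the reverse of what was seen between compound 1 and compound 2: there, removing a basic ring-bearing side chain cost a number 16 percentage points lower from compound 1 to compound 2 (beyond the scatter). Compound 3 reintroduces a side chain of that kind, so a step of similar size upward in this assay is expected, a number 15 percentage points higher from compound 2 to compound 3 (beyond the scatter), with no reason in the data to expect more.

Compound 3 is therefore estimated at 27%, within 10% to 45%.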

Compound 3, a percentage reported as inhibition, at one concentration (the size of the read-out at that concentration, not a potency): 21%
Compound 3: middle estimate off by 6 percentage points, on the high side, within the range that was stated.
By their numbers in this assay, from the lowest: compounds 2, 3 and 1 (each within the scatter of the next, the first and the last beyond it).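

In this assay, (2-(pyrrolidin-1-yl)ethyl)amino on this aromatic carbon, para to a large group, gives a reading not separable from bromo (a number 9 percentage points higher from compound 2 to compound 3 (within the scatter)) and also not separable from (1-methylpiperidin-4-yl)oxy (a number 7 percentage points lower from compound 1 to compound 3 (within the scatter)). Compound 3 therefore cannot be grouped with either compound, and the difference beyond the scatter at this position holds only for the pair of compound 1 and compound 2, not for every amine-bearing side chain against bromo. Nothing measured on these compounds accounts for these readings.

Open, as far as these compounds go, is whether a morpholine ring in place of the pyrrolidine ring, or a longer chain ahead of it, would read clearly apart from bromo. Also open, from the compounds shown here alone, is how a carboxylic acid or a plain amino group on this carbon would read.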